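Chloro for methyl on the anilide ring of compound 1

A few compounds are considered here, and "the series" means these few. Any claim that something is new, unique, unknown or untested is made for them only; others in the source may bear on it.

Measured so far:
compound 1 `Cc1ccc(N2CC(c3nc(-c4cccc(F)c4)no3)CC2=O)cc1` — 1200 nM
compound 2 `Cc1ccc(N2CC(c3nc(-c4cccc(Cl)c4)no3)CC2=O)cc1` — 630 nM

For the measured compounds named here, compound 1 gives the highest of the two numbers so far in an in vitro functional assay on HEK293-A cells for positive allosteric modulation of metabotropic glutamate receptor 5 (Homo sapiens), read by FLIPR and calcium flux; on this read-out lower numbers stand for an effect already at smaller amounts and higher numbers for an effect only at larger amounts of compound; the nearest is compound 2, which differs only by chloro in place of fluoro on an aromatic carbon, and that step a 1.9-fold lower number from compound 1 to compound 2 (0.28 log units; within the scatter) stays within the scatter. Compound 3 `O=C1CC(c2nc(-c3cccc(F)c3)no2)CN1c1ccc(Cl)cc1` is not yet measured. It differs from compound 1 by chloro in place of methyl on an aromatic carbon; cut one bond further out, the change reads 4-methylphenyl to 4-chlorophenyl, on the aromatic carbon of the six-membered carbon-only ring that is para to a large group.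

Going by the values given here, no measured pair shows a methyl-to-chloro exchange, and the only step available, from compound 1 to compound 2, concerns the other aromatic ring and is itself within the scatter. The shown data therefore give no ground to expect a step beyond the scatter in this assay for this change. Compound 3 is estimated at 1000 nM, between 400 nM and 3000 nM, which is expected to amount to a 1.2-fold lower number from compound 1 to compound 3 (0.08 log units; within the scatter).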

Compound 3, half-maximal effective concentration: 630 nM
Beside the measured number, compound 3's estimate is 1.6-fold (0.20 log units) above it, and the stated range covers the measured number.
By their numbers in this assay, from the lowest: compounds 2, 3 and 1 (each within the scatter of the next).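

Chloro in place of methyl, on the aromatic carbon para to a large group, gives in this assay a 1.9-fold lower number from compound 1 to compound 3 (0.28 log units; within the scatter), the first reading at this position. The earlier pair spoke only to the other aromatic ring, where chloro in place of fluoro gave a 1.9-fold lower number from compound 1 to compound 2 (0.28 log units; within the scatter), so the series now has one single exchange on each aromatic ring, and neither lies beyond the scatter. On this one pair, 4-methylphenyl and 4-chlorophenyl cannot be told apart in this assay, and nothing available bears on why that is so.

For the compounds shown here, open is whether any group at this position would move the number beyond the scatter, for instance an amine, a carboxylic acid, a methoxy group or a longer alkyl chain, since methyl and chloro are the only two groups seen here so far. Also open is how the 4-chlorophenyl of compound 3 would read when combined with the 3-chlorophenyl ring of compound 2, a combination that the single exchanges shown cannot predict.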